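Phenyl for Methyl on the Shared Core

This account rests on a few compounds, and the source may have more. Where it says the series, first, only, none or still open, it means among the compounds named here.

Within the data shown here, compound 2 `CO[C@@H]1CC=C2NN(c3cc4ccccc4[nH]3)C(=O)C[C@]2(C)O1` gives 4100 nM in a functional assay on SK-BR-3 cells (Homo sapiens) for inhibition, read by sulforhodamine B assay, with a stated time of 48 h (on this read-out higher numbers stand for weaker inhibition and lower numbers for stronger inhibition), the lowest of the two numbers measured so far; compound 1 `CO[C@@H]1CC=C2NN(c3ccc(C)cc3)C(=O)C[C@]2(C)O1` gives 29700 nM in this assay, a difference well beyond the scatter. Compound 3 `CO[C@@H]1CC=C2NN(c3cc4ccccc4[nH]3)C(=O)C[C@]2(c2ccccc2)O1` differs from compound 2 by phenyl in place of methyl on a saturated ring carbon. Among the measured compounds shown here, no measured pair shows a change of this kind, so its effect cannot be read from the numbers at hand. The step of a 1.2-fold higher number from compound 2 to compound 3 (0.09 log units; within the scatter) is expected to be small, not clearly beyond the scatter. Compound 3 is therefore expected to give about 5000 nM, within a range from 1500 nM to 17000 nM.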

Compound 3, half-maximal inhibitory concentration: 530 nM
The estimate for compound 3 lay 9.4-fold (0.97 log units) above the measured number; measured number outside the range, below it.
By their numbers in this assay, from the lowest: compound 3; then compound 2; then compound 1.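

At this saturated ring carbon next to the ring oxygen, phenyl in place of methyl gives a step in this assay of a 7.7-fold lower number from compound 2 to compound 3 (0.89 log units; beyond the scatter), so the position responds to the change and an aromatic ring of carbon is accepted there. Nothing at hand explains this step. What the compounds shown leave open is whether the gain belongs to phenyl itself or would also come with a cyclohexyl ring or a longer chain at this carbon. They also leave open how a phenyl carrying an amine or a carboxylic acid would read.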